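This account rests on a few compounds, and the source may have more. Where it says the series, first, only, none or still open, it means among the compounds named here.

Two members of the series have been run through a functional assay on T47D cells (Homo sapiens) for cytotoxicity, read by CCK-8 assay; on this read-out lower numbers stand for stronger inhibition and higher numbers for weaker inhibition. Compound 1 `Oc1cccc(-c2cc(-c3ccoc3)cc(-c3ccccc3O)n2)c1` reaches only the limit of the assay, giving > 50000 nM. Compound 2 `Oc1ccccc1-c1cc(-c2ccccn2)cc(-c2ccccc2O)n1` likewise sits at the limit, giving > 50000 nM. Within the data shown here, compound 2 therefore stands where every value so far stands, at a limit rather than a number (the limit of > 50000 nM in this assay, at which 2 of the 2 values shown sit). Compound 3 `Oc1cccc(-c2cc(-c3ccccn3)cc(-c3ccccc3O)n2)c1` differs from compound 2 by 3-hydroxyphenyl in place of 2-hydroxyphenyl on an aromatic carbon. Among the measured compounds shown here, no step between measured compounds is available, so no move beyond the scatter is expected a step that the limit leaves unreadable from compound 2 to compound 3. For compound 3 the estimate is 60000 nM, within 20000 nM to 200000 nM, most likely again reported as a limit.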

Compound 3, half-maximal inhibitory concentration: 2560 nM
For compound 3 the middle estimate is 23-fold (1.37 log units) above the measured one; measured number outside the range, below it.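

3-hydroxyphenyl in place of 2-hydroxyphenyl, next to the ring nitrogen, gives an at least 19-fold lower number from compound 2 to compound 3 (1.29 log units; beyond the scatter), so the placing of the hydroxyl alone, with the same atoms, separates a measurable value from a limit. With 3-hydroxyphenyl held in place, pyridin-2-yl in place of furan-3-yl gives an at least 19-fold lower number from compound 1 to compound 3 (1.29 log units; beyond the scatter), so the other aromatic ring also counts. Each step starts from a limit, so its full size stays unknown: the limit of > 50000 nM in this assay, at which 2 of the 3 values shown sit.

Going by these compounds, whether an amine or a carboxylic acid in place of the hydroxyl on the 3-hydroxyphenyl group would hold this gain remains open.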